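This account rests on a few compounds, and the source may have more. Where it says the series, first, only, none or still open, it means among the compounds named here.

Compound 1, `O=[N+]([O-])c1ccc(-c2noc(Cc3c[nH]c4ccccc34)n2)cc1`, gives in a functional assay on cells (Splenocyte, Mus musculus, strain BALB/c) for inhibition, read by scintillation counting and thymidine incorporation, with stated times of 48 h and 8 h (a higher number here means a weaker inhibitor, a lower number a stronger inhibitor), only a limit, > 50000 nM.
Compound 2, `COc1ccc(Br)c(-c2nc(Cc3c[nH]c4ccccc34)no2)c1`, gives in this assay 13300 nM.
Compound 3, `COc1cc(-c2noc(-c3ccccc3)n2)cc(OC)c1OC`, gives in this assay only a limit, > 50000 nM.

Compound 3 stands at the edge of what this assay can report: its value is a limit, not a number, and it shares this with compound 1, which is told by the limit of > 50000 nM in this assay, at which 2 of the 3 values shown sit. Among the compounds with values here, of the three compounds, only compound 2 gives a measured number, and no pair among the three differs in just one place, so no single step can be measured from these data.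

The piece follows the step from compound 3 to compound 4, `COc1cc(-c2noc(-c3cccc(N)c3)n2)cc(OC)c1OC`. The change is amino in place of hydrogen on an aromatic carbon; cut one bond further out, it reads phenyl to 3-aminophenyl. Within the data shown here, no measured step is available to calibrate such a change in this assay, and compound 3 itself offers only a limit as a starting point. The expected step is therefore none beyond the usual scatter, with a substantial chance that compound 4 also returns only a limit. Compound 4 is estimated at 40000 nM, within a range of 8000 nM to 200000 nM, which means an expected step of an at least 1.2-fold lower number from compound 3 to compound 4 (0.09 log units; that floor lies within the scatter).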

Compound 4, half-maximal inhibitory concentration: 7000 nM
Beside the measured number, compound 4's estimate is 5.7-fold (0.76 log units) above it; measured number outside the range, below it.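

In this assay, this gives the first measured step among the compounds shown: amino in place of hydrogen on an aromatic carbon, meta to a large group, produces an at least 7.1-fold lower number from compound 3 to compound 4 (0.85 log units; beyond the scatter), which shows that this position on the phenyl ring can change the read-out from a limit to a number. Compound 3 gives only a limit, > 50000 nM. The step is therefore a floor and not a full size, and the real distance between the two compounds may be larger, because the starting point lies at the edge of what can be reported: the limit of > 50000 nM in this assay, at which 2 of the 4 values shown sit.

With a single change at a single position, the compounds shown leave open whether this shift belongs to the amino group in particular or would also appear with a hydroxyl, an acetamide or a dimethylamino group in the same place. Within the data shown here, they also leave open whether amino in place of hydrogen would have a similar effect on the core of compound 2 or on that of compound 1, since no pair links those compounds to this step.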